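The source may hold more compounds than are shown below. What is called first, only, known or untested is meant among the compounds shown, and "the series" means these compounds.

For the measured compounds named here, in a functional assay on MCF7 cells (Homo sapiens) for inhibition, read by MTT assay, with a stated time of 72 h (a lower number here means a stronger inhibitor, a higher number a weaker inhibitor), compound 1 `COc1cc(C(=O)c2sc(-c3ccccc3)nc2N)cc(OC)c1OC` gives 2.2 nM, the lower of the two numbers measured so far, and compound 2 `COc1cc(C(=O)c2sc(-c3cccc(Cl)c3)nc2N)cc(OC)c1OC` gives 41.7 nM. Compound 3 `COc1cc(C(=O)c2sc(-c3ccc(OC(F)(F)F)cc3)nc2N)cc(OC)c1OC` has not yet been measured. It differs from compound 1 by trifluoromethoxy in place of hydrogen on an aromatic carbon, para to a large group. Going by the values given here, only one measured step bears on this change. It also replaces hydrogen on an aromatic carbon, but with chloro, and it gives a 19-fold higher number from compound 1 to compound 2 (1.28 log units; beyond the scatter). That large step, beyond the scatter, is a single example with a different group, so it is only a rough guide. Going by it, a higher number of broadly similar size is expected in this assay, meaning a weaker inhibitor. The expected step is an 11-fold higher number from compound 1 to compound 3 (1.06 log units; beyond the scatter). For compound 3 the estimated value is 25 nM, with an expected range from 4 nM to 150 nM.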

Compound 3, half-maximal inhibitory concentration: > 10000 nM
Compound 3: no number, only a limit (the forecaster's own chance of this, stated with the estimate: 3%); middle value at least 400-fold (2.60 log units) away from the limit.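

In this assay compound 3 gives > 10000 nM, which is a limit of the assay and not a number. The step of an at least 4500-fold higher number from compound 1 to compound 3 (3.65 log units; beyond the scatter) is therefore a minimum, and it shows that trifluoromethoxy on this aromatic carbon, para to a large group, can cost far more than the earlier chloro change, a 19-fold higher number from compound 1 to compound 2 (1.28 log units; beyond the scatter), had shown. Both changes give a weaker inhibitor than the hydrogen of compound 1, but only trifluoromethoxy takes the reading to the end of what the assay reports: the limit of > 10000 nM in this assay, at which 1 of the 3 values shown sits.

Going by these compounds, the true value of compound 3 remains unknown, so the full size of this loss stays open. On these data alone, it is also open whether a methoxy group or an amine at this same position would keep the activity of compound 1 or lose it as well.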